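This account rests on a few compounds, and the source may have more. Where it says the series, first, only, none or still open, it means among the compounds named here.

Three close analogues were examined in an assay on isolated protein for inhibition of protein kinase C zeta type (Homo sapiens), with stated times of 1 h and 2.5 min, tested at 30 uM; on this read-out lower numbers stand for less inhibition and higher numbers for more inhibition at the one concentration tested (going by the name of the read-out). Compound 1, `CCOC(=O)c1c(-c2cccc(C)c2)csc1N`, was the first of them; in this assay compound 1 gives 77%. Compound 2, `CCOC(=O)c1c(-c2ccc(C)cc2)csc1N`, is built from the same atoms joined differently; the difference between the two cores is not broken down here. In this assay compound 2 gives 80%. Compound 3, `CCOC(=O)c1c(-c2cccc(OC)c2)csc1N`, arises from compound 1 by the change (methoxy in place of methyl on an aromatic carbon), and in this assay compound 3 gives 82%. The step this change made is a number 5 percentage points higher from compound 1 to compound 3 (within the scatter). Among the three measured compounds, compound 2 sits between the other two, though all three numbers lie within the scatter of one another, so no order among them can be read.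

Compound 4, `CCOC(=O)c1c(-c2ccc(OC)cc2)csc1N`, has not yet been measured in this assay. It arises from compound 2 by the change (methoxy in place of methyl on an aromatic carbon). For the measured compounds named here, this is the same kind of change as the one from compound 1 to compound 3, but not the same: in the earlier case the place is meta to a large group, whereas here it is para to a large group. Because the earlier step of a number 5 percentage points higher from compound 1 to compound 3 (within the scatter) stayed within the scatter, the expected step here is likewise a number 3 percentage points higher from compound 2 to compound 4 (within the scatter), a small one. Resting on compound 2 and its value 80%, compound 4 is estimated to give 83% in this assay, with an expected range from 70% to 93%.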

Compound 4, a percentage reported as inhibition, at one concentration (the size of the read-out at that concentration, not a potency): 100%
For compound 4 the middle estimate is 17 percentage points below the measured one; the whole stated range lies below it.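

In this assay, the change of methyl to methoxy, para to a large group, gave a number 20 percentage points higher from compound 2 to compound 4 (beyond the scatter), so on this core it is a real gain in inhibition at the one concentration tested. The same change did not carry over at one size between the two cores: the same change on two cores in this assay, a number 5 percentage points higher (within the scatter) from compound 1 to compound 3 and a number 20 percentage points higher (beyond the scatter) from compound 2 to compound 4, 15 percentage points apart, beyond the scatter of two such steps

For the compounds shown here, this shows that the step seen on the core of compound 1 could not have been relied on to give the size of the step on the core of compound 2, but it rests on only two pairs, read at a single concentration and not as potencies, and it does not show why the two steps differ or whether a rule holds beyond these four compounds.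

The compounds shown leave open how an ethoxy group, a longer chain or a hydroxyl group would behave at the same place on the aromatic ring, and so whether the gain belongs to methoxy alone. They also leave open what would happen on the shared core if a carboxylic acid or an amide stood in place of the ethyl ester.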